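This account rests on a few compounds, and the source may have more. Where it says the series, first, only, none or still open, it means among the compounds named here.

In a physicochemical assay for lipophilicity, at pH 7.4 (on this read-out lower numbers stand for lower lipophilicity and higher numbers for higher lipophilicity), compound 1 (`C[C@H]1C(=O)N(C)C=Cc2cc(C(CO)CO)ccc21`) gives 1.2, compound 2 (`CCS(=O)(=O)c1ccc2c(c1)C(c1cnn(C)c1)=CN(C)C(=O)[C@@H]2C`) gives 2.8 and compound 3 (`CCOc1ccc2c(c1)C(c1cnn(C)c1)=CN(C)C(=O)[C@@H]2C`) gives 4.1, the highest of the three numbers. Going by the values given here, the one measured single-place step is a number 1.30 log units higher from compound 2 to compound 3 (beyond the scatter), with ethoxy in place of ethylsulfonyl on an aromatic carbon. Compound 4 (`CCOc1ccc2c(c1)C(c1c[nH]cn1)=CN(C)C(=O)[C@@H]2C`) retains the ethoxy and differs from compound 3 elsewhere: 1H-imidazol-4-yl in place of 1-methyl-1H-pyrazol-4-yl on a double-bonded ring carbon, on a double-bonded ring carbon of a seven-membered non-aromatic ring. Among the compounds with values here, no measured step covers a change at this place, so the step between compound 2 and compound 3, a number 1.30 log units higher from compound 2 to compound 3 (beyond the scatter), serves only as a sense of scale and not as a direct precedent. The expectation therefore rests mainly on the counted difference between the two groups, and it is uncertain. A moderate fall in this assay is expected, smaller than that large step. The expected change is a number 0.70 log units lower from compound 3 to compound 4 (beyond the scatter). For compound 4 the estimate is 3.4, with an expected range of 2.9 to 3.9.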

Compound 4, distribution coefficient: 2.7
Compound 4: middle estimate off by 0.70 log units, on the high side; the measured number lies below the stated range.
By their numbers in this assay, from the lowest: compound 1; then compounds 4 and 2 (each within the scatter of the next); then compound 3.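

Going by these compounds alone, the double-bonded ring carbon of the seven-membered non-aromatic ring, a place no earlier step covered, proves highly sensitive in this assay: with the ethoxy kept, 1H-imidazol-4-yl in place of 1-methyl-1H-pyrazol-4-yl gives a number 1.40 log units lower from compound 3 to compound 4 (beyond the scatter). This step is of similar size to a number 1.30 log units higher from compound 2 to compound 3 (beyond the scatter), so a swap between two five-membered aromatic rings here counts for about as much as replacing ethylsulfonyl with ethoxy on the aromatic carbon. Nothing available bears on the reason for the size of this step.

Open, as far as these compounds go, is how much of the step goes with the hydrogen-bond donor that the entering group carries and how much with the change from pyrazolyl to imidazolyl; 1H-pyrazol-4-yl or 1-methyl-1H-imidazol-4-yl at this carbon would separate the two. Also open, from the compounds shown here alone, is whether the same swap gives a step of this size with ethylsulfonyl in place of ethoxy.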